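Compound 3 to compound 4: a benzyloxycarbonyl swap

A few compounds are considered here, and "the series" means these few. Any claim that something is new, unique, unknown or untested is made for them only; others in the source may bear on it.

Measured so far in a functional assay on B16 cells (Mus musculus) for cytotoxicity, read by MTT assay, with a stated time of 48 h (a higher number here means a weaker inhibitor, a lower number a stronger inhibitor), are these:
- compound 1 `C#Cc1cccc(NC(=O)c2cn(Cc3ccccc3)nn2)c1` gives 14500 nM
- compound 2 `CCOC(=O)Cn1cc(CNC(=O)c2cn(Cc3ccccc3)nn2)nn1` gives 35000 nM
- compound 3 `CC(=O)OCCn1cc(CNC(=O)c2cn(Cc3ccccc3)nn2)nn1` gives 28000 nM

Compound 3 stands within the scatter of both compound 1 and compound 2. Compound 4 `CC(=O)OCCn1cc(CNC(=O)c2cn(CC(=O)OCc3ccccc3)nn2)nn1` carries benzyloxycarbonyl in place of phenyl on a saturated chain carbon bound to an aromatic nitrogen, counted as benzyloxycarbonyl in place of phenyl on a saturated chain carbon bound to an aromatic nitrogen in full. Among the measured compounds shown here, the one measured step, a 1.3-fold lower number from compound 2 to compound 3 (0.10 log units; within the scatter) for a change elsewhere, is small, and no measured step touches this phenyl. With so little to go on, no shift beyond the scatter is expected in this assay and the estimated move is a 1.1-fold lower number from compound 3 to compound 4 (0.05 log units; within the scatter) at most a guess. For compound 4 the estimated value is 25000 nM with an expected range from 10000 nM to 60000 nM as the likely span.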

Compound 4, half-maximal inhibitory concentration: > 100000 nM
Compound 4 was reported as a limit; the forecaster's own chance of this, stated with the estimate: 8%; at least 4.0-fold (0.60 log units) between middle value and limit.
By their numbers in this assay, from the lowest: compounds 1, 3 and 2 (each within the scatter of the next, the first and the last beyond it). At a limit, above all of these: compound 4.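

In this assay, the place on a saturated chain carbon bound to an aromatic nitrogen responds to change: benzyloxycarbonyl in place of phenyl gives an at least 3.5-fold higher number from compound 3 to compound 4 (0.55 log units; beyond the scatter). The earlier step at another place, a 1.3-fold lower number from compound 2 to compound 3 (0.10 log units; within the scatter), gave no such sign. The reading for compound 4 is a limit and not a number: the limit of > 100000 nM in this assay, at which 1 of the 4 values shown sits.

Left open is how far the number for compound 4 actually lies from that of compound 3. Also open, from the compounds shown here alone, is whether a longer chain ending in phenyl, a carboxylic acid or an amine at this place would read like phenyl or like benzyloxycarbonyl.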